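The compounds below may be only part of what the source reports. "The series", "measured", "known", "first", "only" and "open" are said of these compounds alone.

Working notes on the series. Compound 1 `COc1cc(C2CC(c3ccc(Br)cc3)=NN2C(C)=O)cc(OC)c1OC` and compound 3 `COc1cc(C2CC(c3ccco3)=NN2C(C)=O)cc(OC)c1OC` share one core. In a functional assay on PC-3 cells (Homo sapiens) for cytotoxicity, read by sulforhodamine B assay, with a stated time of 48 h (on this read-out higher numbers stand for weaker inhibition and lower numbers for stronger inhibition), compound 1 gives 3450 nM, and in this assay compound 3 gives 9650 nM; the change furan-2-yl in place of 4-bromophenyl on a carbon with a double bond to nitrogen gave a 2.8-fold higher number from compound 1 to compound 3 (0.45 log units; beyond the scatter). Compound 2 `CC(=O)N1N=C(c2ccc(Br)cc2)CC1c1cccc(Cl)c1Cl` gives 38800 nM in this assay, the highest number of the three; the difference between the core of compound 2 and that of compound 1 is not broken down here. Compound 4 `CC(=O)N1N=C(c2ccco2)CC1c1cccc(Cl)c1Cl` is not yet measured and differs from compound 2 by furan-2-yl in place of 4-bromophenyl on a carbon with a double bond to nitrogen. The surroundings differ only in that the ring atom bears a group of 8 heavy atoms here and a large group in compound 1, so this is the same kind of change. The step is expected to be a 2.4-fold higher number from compound 2 to compound 4 (0.39 log units; beyond the scatter) because the same change gave a 2.8-fold higher number from compound 1 to compound 3 (0.45 log units; beyond the scatter). Compound 4 is estimated at 95000 nM in this assay, expected between 35000 nM and 250000 nM.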

Compound 4, half-maximal inhibitory concentration: 61200 nM
Compound 4: the middle estimate sits 1.6-fold (0.19 log units) above what was measured; measured number inside the range.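

In this assay, furan-2-yl in place of 4-bromophenyl gives a 1.6-fold higher number from compound 2 to compound 4 (0.20 log units; within the scatter), and this step cannot be told apart from the one on the core of compound 1: the same change on two cores in this assay, a 2.8-fold higher number (0.45 log units; beyond the scatter) from compound 1 to compound 3 and a 1.6-fold higher number (0.20 log units; within the scatter) from compound 2 to compound 4, 1.8-fold (0.25 log units) apart, within the scatter of two such steps. Taken alone, the step on the core of compound 2 does not establish a difference between the two compounds. The comparison rests on two pairs in one assay, so it shows agreement within the scatter on these two cores, not equal steps or a rule for other cores.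

Open, on these data alone, is how an amine-bearing ring such as 4-aminophenyl would compare on a carbon with a double bond to nitrogen. Also open, as far as these compounds go, is how a longer chain such as propanoyl would compare in place of the acetyl group.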